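The source may hold more compounds than are shown below. What is called first, only, known or untested is meant among the compounds shown, and "the series" means these compounds.

Of the compounds shown here, three have been tested in a functional assay on COLO 205 cells (Homo sapiens) for inhibition, read by sulforhodamine B assay, with a stated time of 48 h, tested at 50 uM; on this read-out lower numbers stand for less inhibition of growth and higher numbers for more inhibition of growth at the one concentration tested. Compound 1 `O=C1C(=O)N(CCCCn2cc(COc3cc(=O)oc4ccccc34)nn2)c2ccc(Br)cc21` gives 56% in this assay. Compound 2 `O=C1C(=O)N(CCCn2cc(COc3cc(=O)oc4ccccc34)nn2)c2ccc(F)cc21` gives 69% in this assay, and compound 3 `O=C1C(=O)N(CCCCn2cc(COc3cc(=O)oc4ccccc34)nn2)c2ccc(F)cc21` gives 64% there. Compound 3 and compound 1 differ in one place, (bromo in place of fluoro on an aromatic carbon), and this change made a step of a number 8 percentage points lower from compound 3 to compound 1 (within the scatter). Compound 4 `O=C1C(=O)N(CCCn2cc(COc3cc(=O)oc4ccccc34)nn2)c2ccc(Br)cc21` has not yet been measured in this assay. It differs from compound 2 by the same change, (bromo in place of fluoro on an aromatic carbon), which occurs twice among these four compounds. How the core of compound 2 differs from the core of compound 3 is not broken down here. Resting on the earlier step of a number 8 percentage points lower from compound 3 to compound 1 (within the scatter), the step from compound 2 to compound 4 is expected to be a number 8 percentage points lower from compound 2 to compound 4 (within the scatter). Compound 4 is thus estimated at 61% in this assay, most likely between 50% and 72%.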

Compound 4, percent growth inhibition at one concentration: 61%
Estimate against measurement, compound 4: no gap at the digits printed; the range from low to high includes it.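

In this assay, bromo in place of fluoro on an aromatic carbon made a step of a number 8 percentage points lower from compound 2 to compound 4 (within the scatter). Set beside the earlier step, the change carried from one core to the other with no visible difference: the same change on two cores in this assay, a number 8 percentage points lower (within the scatter) from compound 3 to compound 1 and a number 8 percentage points lower (within the scatter) from compound 2 to compound 4, 0 percentage points apart, within the scatter of two such steps. Both steps lie within the scatter, however, and two cores alone show neither that the change has an effect of its own nor that it would carry to any other core.

The compounds shown carry only fluoro or bromo at this place, so it remains open how chloro, methoxy or a nitrile there would read in this assay. Also open, on these data alone, is how a longer chain, or an amine on the chain, would read.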